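The compounds below may be only part of what the source reports. "The series", "measured", "known", "first", "only" and "open" are said of these compounds alone.

Compound 1 , `CCOC(=O)C1(Cc2ccccc2)CN(c2ccccc2)Cc2nnn(CCCCCO)c21`, is measured in an ADME assay on HEL cells (Homo sapiens) for cytotoxicity, read by microscopy, with a stated time of 3 days (a lower number here means that less compound is tolerated, a higher number that more compound is tolerated), and gives only a limit, > 100000 nM.
Compound 2 , `CCOC(=O)C1(Cc2ccc(F)cc2)CN(c2ccccc2)Cc2nnn(Cc3cccc(F)c3)c21`, gives in this assay only a limit, > 100000 nM.
Compound 3 , `c1ccc(N2CCc3c(nnn3CC3CC3)C2)cc1`, gives in this assay only a limit, > 100000 nM.

Compound 3 therefore stands where every measured compound in this set stands: at the upper limit of this assay, with no number of its own. The same holds for the two others, as the limit of > 100000 nM in this assay, at which 3 of the 3 values shown sit, records, so there is no measured step between any pair of these compounds, and no direction of change can be read from them.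

Compound 4 , `CCCCCCn1nnc2c1CCN(c1ccccc1)C2`, is not yet measured. It differs from compound 3 in one place: pentyl in place of cyclopropyl on a saturated chain carbon bound to an aromatic nitrogen. Nothing in the measured set tells how a pentyl in place of a cyclopropyl on a saturated chain carbon bound to an aromatic nitrogen moves the read-out, since all three measured values sit at the limit.

The expectation for compound 4 is accordingly conservative. The step of a number no higher from compound 3 to compound 4 (the limit leaves the size open) is expected to be none beyond the usual scatter, with the result most likely reported again as a limit. In this assay compound 4 is expected to give about 100000 nM, within a range from 30000 nM to 200000 nM.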

Compound 4, minimum cytotoxic concentration: > 100000 nM
Compound 4 gave a limit, no number (the forecaster's own chance of this, stated with the estimate: 80%); the middle value sits exactly at the limit.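

Compound 3 and compound 4 both give only a limit, so no new step can be read between them, and the change from cyclopropyl to pentyl has no measurable size here: the limit of > 100000 nM in this assay, at which 4 of the 4 values shown sit.

The compounds shown leave open what number any of them would give in this assay, and whether any change on the shared core moves it.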